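The source may report more compounds than this note shows. Statements on the series, on what has been measured and on what is new or still open speak of the compounds shown alone.

Measured compounds in an assay (Cricetulus griseus) for inhibition of aldehyde dehydrogenase, mitochondrial (Homo sapiens); a lower number here means a stronger inhibitor, a higher number a weaker inhibitor:
- compound 1, `NCCCCCCOc1ccc2c(=O)c(-c3ccc(O)cc3)coc2c1`: 100 nM
- compound 2, `O=C(O)CCCCCCCOc1ccc2c(=O)c(-c3ccc(O)cc3)coc2c1`: 40 nM
- compound 3, `O=C(O)CCCCOc1ccc2c(=O)c(-c3ccc(O)cc3)coc2c1`: 100 nM

Compound 3 stands level with compound 1, the two together the highest numbers of the three; compound 2 sits apart, the step of a 2.5-fold higher number from compound 2 to compound 3 (0.40 log units; beyond the scatter) being the only one beyond the scatter, while no change at the digits printed from compound 1 to compound 3 (within the scatter) stays within it.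

Compound 4, `CCCCCCCCCCCCOc1ccc2c(=O)c(-c3ccc(O)cc3)coc2c1`, follows from compound 3 by octyl in place of carboxy on a saturated chain carbon, four bonds along the chain from an oxygen on an aromatic ring. Of the measured steps, a 2.5-fold higher number from compound 2 to compound 3 (0.40 log units; beyond the scatter) shows that a longer chain on this carbon went with a lower number, and no change at the digits printed from compound 1 to compound 3 (within the scatter) that exchanging the chain end left the number unchanged. Among the compounds with values here, no measured step removes every donor and acceptor from the chain. A modest step downward, a 1.7-fold lower number from compound 3 to compound 4 (0.22 log units; within the scatter), is therefore expected. Compound 4 is estimated at 60 nM, within 20 nM to 250 nM.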

Compound 4, half-maximal inhibitory concentration: > 9000 nM
Compound 4 was reported as a limit; the forecaster's own chance of this, stated with the estimate: 5%; middle value at least 150-fold (2.17 log units) from the limit.
By their numbers in this assay, from the lowest: compound 2; then compounds 1 and 3 (each within the scatter of the next). At a limit, above all of these: compound 4.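

In this assay, compound 4 is reported only as a limit of the assay: the limit of > 9000 nM in this assay, at which 1 of the 4 values shown sits.

Replacing the chain end with a plain alkyl chain gives an at least 90-fold higher number from compound 3 to compound 4 (1.95 log units; beyond the scatter), an at least 220-fold higher number from compound 2 to compound 4 (2.35 log units; beyond the scatter) and an at least 90-fold higher number from compound 1 to compound 4 (1.95 log units; beyond the scatter), all far larger than any earlier step in the series. Among these four compounds, chain length alone therefore does not set the number: the chains ending in amino or carboxy keep it, while the one with 0 hydrogen-bond donors and 0 hydrogen-bond acceptors in that end does not.

Still open, going by these compounds, is whether a chain ending in hydroxyl or a primary amide keeps the number. Also open, on these data alone, is whether a shorter plain chain such as butyl loses as much.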